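A few compounds are considered here, and "the series" means these few. Any claim that something is new, unique, unknown or untested is made for them only; others in the source may bear on it.

Measured so far:
compound 1 `COc1ccc(-c2cc(/C=C/C(=O)c3ccc(N)cc3)[nH]n2)cc1` — 4720 nM
compound 2 `COc1cc(-c2cc(/C=C/C(=O)c3ccc(N)cc3)[nH]n2)cc(OC)c1OC` — 2990 nM
compound 3 `COc1ccc(C(=O)/C=C/c2cc(-c3cc(OC)c(OC)c(OC)c3)n[nH]2)cc1OC` — 2790 nM

These three compounds share a core and were compared in a functional assay on SK-OV-3 cells (Homo sapiens) for inhibition, read by sulforhodamine B assay, with a stated time of 48 h; on this read-out higher numbers stand for weaker inhibition of growth and lower numbers for stronger inhibition of growth. On these numbers compound 2 stands second highest of three; its nearest neighbour is compound 3, and the furthest from it is compound 1, but both gaps lie within the scatter, so no order among the three can be read from them.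

Compound 4 `COc1ccc(-c2cc(/C=C/C(=O)c3ccc(N)cc3)[nH]n2)cc1OC` is not yet measured. It differs from compound 2 in one place: hydrogen in place of methoxy on an aromatic carbon. Among the compounds with values here, no measured step removes a methoxy group in this way. Within the data shown here, the one measured step, a 1.1-fold lower number from compound 2 to compound 3 (0.03 log units; within the scatter), changes the other end of the molecule and lies within the scatter. Compound 1 and compound 2, which differ in two places on the same ring, also give numbers within the scatter of each other. Taken together, these values give no reason to expect a step beyond the scatter in this assay.

Compound 4 is therefore estimated at 3400 nM, with a range from 1500 nM to 8000 nM, which means an expected step of a 1.1-fold higher number from compound 2 to compound 4 (0.06 log units; within the scatter).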

Compound 4, concentration for 50% growth inhibition: 4860 nM
The estimate for compound 4 lay 1.4-fold (0.16 log units) below the measured number; the measured number falls inside the stated range.
By their numbers in this assay, from the lowest: compounds 3, 2, 1 and 4 (each within the scatter of the next).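

In this assay, within the data shown here, compound 4 gives the first direct reading at this position: hydrogen in place of methoxy on an aromatic carbon, ortho to a methoxy group, gives a 1.6-fold higher number from compound 2 to compound 4 (0.21 log units; within the scatter) and so does not separate the two compounds. The matching change on the other side, methoxy in place of hydrogen on an aromatic carbon, gives a 1.0-fold higher number from compound 1 to compound 4 (0.01 log units; within the scatter) and does not separate those two either. Among these compounds, no measured property bears on these results, so the numbers show only that both changes stay within the usual scatter and offer no explanation.

The compounds shown leave open whether a hydroxyl group, a fluorine atom or a longer ethoxy chain on this aromatic carbon would give a step beyond the scatter. They also leave open whether removing this methoxy group would read the same with the 3,4-dimethoxyphenyl group of compound 3 on the carbonyl carbon.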